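The source may report more compounds than this note shows. Statements on the series, on what has been measured and on what is new or still open speak of the compounds shown alone.

Compound 1, `O=C(CCCCCCNc1c(Nc2ccccc2)c(=O)c1=O)NO`, and compound 2, `O=C(CCCCCNc1c(Nc2ccccc2)c(=O)c1=O)NO`, share one core and differ only in the length of a saturated chain. In an ADME assay on cells (Hepatocyte, Homo sapiens) for pharmacokinetics, read by LC-MS, with a stated time of 90 min, tested at 1 uM (a higher number here means faster removal of the compound, a lower number slower removal), compound 1 gives < 5 uL/min, which is a limit of the assay rather than a number. In this assay compound 2 gives < 4.8 uL/min, again a limit rather than a number. The step that the two limits leave unreadable from compound 1 to compound 2 therefore cannot be read in size. For the measured compounds named here, compound 2 thus stands at a limit, and the one other value shown is also a limit, as recorded in the limit of < 4.8 uL/min in this assay, at which 1 of the 2 values shown sits, and (the limit of < 5 uL/min in this assay, at which 1 of the 2 values shown sits).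

Compound 3, `O=C(CCCCNc1c(Nc2ccccc2)c(=O)c1=O)NO`, is not yet measured in this assay. Its difference from compound 2 is this: hydroxycarbamoyl in place of (hydroxycarbamoyl)methyl on a saturated chain carbon, four bonds along the chain from a nitrogen on an aromatic ring. The only measured step that bears on this change is the one shown above, and with both of its ends at limits it gives no size to carry forward. No step beyond the scatter is expected from shortening the chain by one more link. Compound 3 is therefore expected to give 3 uL/min, within a range from 1 uL/min to 8 uL/min, most likely reported as a limit once more. This estimate means a step that the limit leaves unreadable from compound 2 to compound 3, expected to lie within the scatter.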

Compound 3, intrinsic clearance in a liver preparation (reported as CLH), per the amount of preparation that the assay uses: < 5 uL/min
Compound 3 gave a limit, no number; the forecaster's own chance of this, stated with the estimate: 80%; the middle value lies beyond the limit too.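

Compound 1, compound 2 and compound 3 all stand at limits in this assay rather than at numbers, so no step among these compounds can be read in size. The compounds shown leave open whether the length of the saturated chain makes any difference to how fast these compounds are removed.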